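This account rests on a few compounds, and the source may have more. Where it says the series, first, only, none or still open, it means among the compounds named here.

Measured in a functional assay on MDA-MB-231 cells (Homo sapiens) for antiproliferative activity, read by MTT assay, with a stated time of 48 h; on this read-out lower numbers stand for stronger inhibition and higher numbers for weaker inhibition:
- Compound 1 `COc1ccc(N(C)c2ccnc(Cl)n2)cc1Cl`: 1380 nM
- Compound 2 `COc1ccc(N(C)c2ccnc(Cl)n2)cc1OCCCCBr`: 992 nM

Compound 2 stands level with compound 1 within the scatter. Compound 3 `COc1ccc(N(C)c2ccnc(Cl)n2)cc1OCC[Se]C#N` carries a group of 3 heavy atoms (1 carbon, 1 nitrogen, 1 selenium; no ring) in place of a group of 3 heavy atoms (2 carbon, 1 bromine; no ring), on a saturated chain carbon, two bonds along the chain from an oxygen on an aromatic ring. Among the compounds with values here, only one measured step bears on this change, and only loosely: a 1.4-fold lower number from compound 1 to compound 2 (0.14 log units; within the scatter). Within the data shown here, that step was made on an aromatic carbon, not on the chain, and no measured compound carries the entering group. No step beyond the scatter is therefore expected, though with wide uncertainty. The expected step is a 1.7-fold lower number from compound 2 to compound 3 (0.22 log units; within the scatter). For compound 3 the estimated value is 600 nM, with an expected range of 100 nM to 1500 nM.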

Compound 3, half-maximal inhibitory concentration: 2750 nM
Estimate against measurement, compound 3: 4.6-fold (0.66 log units) below, and the stated range ends below it.
By their numbers in this assay, from the lowest: compounds 2, 1 and 3 (each within the scatter of the next, the first and the last beyond it).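

In this assay, within the data shown here, the group of carbon, nitrogen and selenium in place of 2-bromoethyl on the chain gives the first step beyond the scatter in this set, a modest loss of inhibition seen as a 2.8-fold higher number from compound 2 to compound 3 (0.44 log units; beyond the scatter) on this read-out. Against the chloro starting point, the full side chain of compound 3 gives no clear change, since a 2.0-fold higher number from compound 1 to compound 3 (0.30 log units; within the scatter) remains within the scatter. Nothing available explains the loss. The compounds shown leave open how an amine or a carboxylic acid would read on this chain carbon. They also leave open whether a longer chain ending in the same selenium group would match compound 2.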